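Ether-linked side chain in place of isopropyl

This account rests on a few compounds, and the source may have more. Where it says the series, first, only, none or still open, it means among the compounds named here.

Compound 2 `CC(C)CNC(=O)n1c(=O)oc2cc(C3CCN(C)CC3)ccc21` gives 166 nM in an assay on HEK293 cells for inhibition of acid ceramidase (Homo sapiens), read by fluorescence, with stated times of 10 min and 3 h (a higher number here means a weaker inhibitor, a lower number a stronger inhibitor), and is the lower of the two numbers recorded so far; its nearest neighbour is compound 1 `CCOCCNC(=O)n1c(=O)oc2cc(C3CCN(C)CC3)ccc21`, which in this assay gives 1050 nM. For the measured compounds named here, the only measured step that bears on the present change is a 6.3-fold lower number from compound 1 to compound 2 (0.80 log units; beyond the scatter). Compound 3 `CN1CCC(c2ccc3c(c2)oc(=O)n3C(=O)NCCOCc2ccccc2)CC1` differs from compound 2 in one place: (benzyloxy)methyl in place of isopropyl on a saturated chain carbon bound to an amide-type nitrogen. Going by the values given here, this brings back an ether oxygen of the kind compound 1 carries, while the benzyl part has no precedent among the measured compounds, so its contribution is unknown. Since compound 1 sits at 1050 nM, the expectation for compound 3 is a shift toward the weaker side, estimated as a 3.0-fold higher number from compound 2 to compound 3 (0.48 log units; beyond the scatter), kept smaller than the measured step to allow for the untested benzyl group. Compound 3 is thus expected to give about 500 nM, with a range of 150 nM to 1600 nM.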

Compound 3, half-maximal inhibitory concentration: 215 nM
Compound 3: the middle estimate sits 2.3-fold (0.37 log units) above what was measured; low and high end bracket the measured number.
By their numbers in this assay, from the lowest: compounds 2 and 3 (each within the scatter of the next); then compound 1.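

In this assay, the (benzyloxy)methyl group is tolerated at this position, on a saturated chain carbon bound to an amide-type nitrogen: a 1.3-fold higher number from compound 2 to compound 3 (0.11 log units; within the scatter) leaves compound 3 level with compound 2 despite the added six-membered aromatic ring. The ether oxygen does not on its own carry the number seen for compound 1, since compound 3 has the oxygen as well. For the compounds shown here, at the far end of the ether chain, the change from methyl to phenyl gives a 4.9-fold lower number from compound 1 to compound 3 (0.69 log units; beyond the scatter) and is the first change here to offset the gap that compound 1 shows.

A 4-phenylbutyl chain, all carbon, would show whether the oxygen matters once the phenyl is present, and a substituted benzyl group would test how much of that end can vary. No measurement shown here explains the effect of either group.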